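From Methoxy to Methyl: Following One Small Swap

This account rests on a few compounds, and the source may have more. Where it says the series, first, only, none or still open, it means among the compounds named here.

Two related compounds have so far been tested in a functional assay on A549 cells (Homo sapiens) for antiproliferative activity, read by MTT assay, with a stated time of 48 h; on this read-out lower numbers stand for stronger inhibition and higher numbers for weaker inhibition. There, compound 1 (`Cc1ccc2nc(NC(c3cn(-c4ccccc4)nc3-c3cccc(Cl)c3)c3c(O)ccc4ccccc34)sc2c1`) gives 45400 nM, and compound 2 (`COc1ccc2nc(NC(c3cn(-c4ccccc4)nc3-c3ccc([N+](=O)[O-])cc3)c3c(O)ccc4ccccc34)sc2c1`) gives 22500 nM. These two values lie within the usual scatter of each other, so compound 2 cannot be separated from compound 1 on these numbers.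

The next molecule, compound 3 (`Cc1ccc2nc(NC(c3cn(-c4ccccc4)nc3-c3ccc([N+](=O)[O-])cc3)c3c(O)ccc4ccccc34)sc2c1`), keeps compound 2 intact except at one place. The swap turns the 6-methoxy-1,3-benzothiazol-2-yl group into 6-methyl-1,3-benzothiazol-2-yl: methyl in place of methoxy on an aromatic carbon.

Within the data shown here, no measured pair yet shows what this single change does, so the data offer no direct guide. The nearest clue is compound 1, which carries the same methyl group and gives 45400 nM, although it differs from compound 2 elsewhere too. No shift beyond the scatter is therefore expected in this assay, and the expected step is a 1.2-fold higher number from compound 2 to compound 3 (0.09 log units; within the scatter). For compound 3 the estimated value is 28000 nM, with an expected range from 12000 nM to 62000 nM.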

Compound 3, half-maximal inhibitory concentration: 29000 nM
For compound 3 the middle estimate is 1.0-fold (0.02 log units) below the measured one; measured number inside the range.
By their numbers in this assay, from the lowest: compounds 2, 3 and 1 (each within the scatter of the next).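

In this assay, this pair finally isolates the swap of methoxy for methyl on an aromatic carbon, and the result is a 1.3-fold higher number from compound 2 to compound 3 (0.11 log units; within the scatter), so at this position the two groups cannot be told apart in this test of cell growth. Compound 3 also forms a second single-change pair, this time at a different place in the molecule: 4-nitrophenyl in place of 3-chlorophenyl gives a 1.6-fold lower number from compound 1 to compound 3 (0.19 log units; within the scatter), and this step likewise cannot be separated from repeat-measurement noise, so neither change shown here has a readable effect on the number. No other data are available that bear on these results.

On these data alone, what remains open is whether this position responds at all, since only methoxy and methyl have been compared there, and a group of a different kind, such as an amine, a carboxylic acid or a longer chain like butoxy, might produce a step beyond the scatter. As far as these compounds go, it is also open whether the swap from methoxy to methyl would read the same with 3-chlorophenyl in place of the 4-nitrophenyl group.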